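The compounds below may be only part of what the source reports. "The series", "measured", "known", "first", "only" and "open" are said of these compounds alone.

Compound 1 `O=C1CC(c2nc(-c3cccc(F)c3)no2)CN1c1ccc(Cl)cc1` gives 630 nM in an in vitro functional assay on HEK293-A cells for positive allosteric modulation of metabotropic glutamate receptor 5 (Homo sapiens), read by FLIPR and calcium flux; a higher number here means that more compound is needed for the effect, a lower number that less compound is needed.
Compound 2 `O=C1CC(c2nc(-c3ccccn3)no2)CN1c1ccc(F)cc1` gives only a limit of the assay in this assay, > 10000 nM.
Compound 3 `Cc1ccc(N2CC(c3nc(-c4cccc(C)c4)no3)CC2=O)cc1` gives 1300 nM in this assay.

Among the two compounds that return a number, compound 1 carries the lower one; compound 3 sits higher, by a gap that lies beyond the usual scatter of repeated runs. The value of compound 2 is a limit and not a number, so it adds no further point of comparison: it only shows that one of the three results stops at the limit of > 10000 nM in this assay, at which 1 of the 3 values shown sits.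

Compound 4 `O=C1CC(c2nc(-c3cccc(Cl)c3)no2)CN1c1ccc(Cl)cc1` shares the core of compound 1 and differs from it in one place: chloro in place of fluoro on an aromatic carbon. Among the measured compounds shown here, no pair of measured compounds shows this exact change, so the size of the step can only be expected rather than read off. The account expects a small step in this assay, toward a somewhat lower number for compound 4 than for compound 1, though one that may well stay within the scatter. On that basis the estimate for compound 4 is 450 nM, with a range from 200 nM to 1100 nM, which corresponds to an expected step of a 1.4-fold lower number from compound 1 to compound 4 (0.15 log units; within the scatter).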

Compound 4, half-maximal effective concentration: 140 nM
The estimate for compound 4 lay 3.2-fold (0.51 log units) above the measured number, and the stated range ends above it.
By their numbers in this assay, from the lowest: compound 4; then compound 1; then compound 3. At a limit, above all of these: compound 2.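

Chloro in place of fluoro on an aromatic carbon, meta to a large group, gives a 4.5-fold lower number from compound 1 to compound 4 (0.65 log units; beyond the scatter) in this assay, which shows that the number in this assay responds to which of these two halogens sits at this place on the ring. Among the compounds shown here, the earlier compounds could not show this, since no two of them differed in one place only; compound 1 and compound 4 form the one pair here that ties a change in the number to a single exchange, with the rest of the structure held the same. Nothing measured here speaks to why this exchange moves the number as it does.

How the number would respond to a bromo, a methoxy, a trifluoromethyl or a nitrile at this same place remains open, so the compounds shown give no trend across groups, only one step between two halogens. Also open, going by these compounds, is whether the exchange from 3-fluorophenyl to 3-chlorophenyl would give a step of similar size on a compound that differs from compound 1 elsewhere in its structure.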